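Swapping the bromine at the chain end of compound 2

The source may report more compounds than this note shows. Statements on the series, on what has been measured and on what is new or still open speak of the compounds shown alone.

In a functional assay on A549 cells (Homo sapiens) for antiproliferative activity, read by MTT assay, with a stated time of 48 h (on this read-out higher numbers stand for weaker inhibition and lower numbers for stronger inhibition), compound 1 (`COc1ccc(N(C)c2ccnc(Cl)n2)cc1OCCBr`) gives 4640 nM and compound 2 (`COc1ccc(N(C)c2ccnc(Cl)n2)cc1OCCCCBr`) gives 591 nM as the lower of the two numbers. For the measured compounds named here, the one measured step (a 7.9-fold lower number from compound 1 to compound 2 (0.89 log units; beyond the scatter)) lengthens the chain and keeps the bromine, so it is only a loose guide to what a change at the chain end will do. Going by the values given here, compound 3 (`COc1ccc(N(C)c2ccnc(Cl)n2)cc1OCCCC[Se]C#N`) carries a group of 3 heavy atoms (1 carbon, 1 nitrogen, 1 selenium; no ring) in place of one bromine atom, on a saturated chain carbon, four bonds along the chain from an oxygen on an aromatic ring as its one change. In this assay a modest further drop is expected (a 3.0-fold lower number from compound 2 to compound 3 (0.47 log units; beyond the scatter)), no larger than the measured step. The estimated value for compound 3 is 200 nM (range 40 nM to 800 nM).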

Compound 3, half-maximal inhibitory concentration: > 10000 nM
Compound 3 was reported as a limit (the forecaster's own chance of this, stated with the estimate: 2%); middle value at least 50-fold (1.69 log units) from the limit.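

Compound 3 sits at a limit of the assay, not at a number: the limit of > 10000 nM in this assay, at which 1 of the 3 values shown sits. At the chain end, the group of 3 heavy atoms (1 carbon, 1 nitrogen, 1 selenium) in place of bromo gives an at least 16-fold higher number from compound 2 to compound 3 (1.22 log units; beyond the scatter), so this end group, and not only chain length, moves the number. The same group also falls behind the shorter bromo compound, with an at least 2.1-fold higher number from compound 1 to compound 3 (0.33 log units; beyond the scatter).

From the compounds shown here alone, whether an amine, a carboxylic acid or a chloro atom at this chain end would keep the activity stays open. So does how far past the limit compound 3 truly lies.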